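Cyano for fluoro on the amide aryl of an imidazole series

A few compounds are considered here, and "the series" means these few. Any claim that something is new, unique, unknown or untested is made for them only; others in the source may bear on it.

Measured compounds:
compound 1, `Cn1c(-c2ccc(C#N)cc2)cnc1NC(=O)c1ccc(F)cc1`: > 50000 nM
compound 2, `Cn1c(-c2ccc(F)cc2)cnc1NC(=O)c1ccc(F)cc1`: > 100000 nM
compound 3, `COc1ccc(-c2cnc(NC(=O)c3ccccc3F)n2C)cc1`: > 100000 nM

In a toxicity assay on THP-1 cells (Homo sapiens) for inhibition (a lower number here means that less compound is tolerated, a higher number that more compound is tolerated), compound 2 reaches only a limit of the assay, > 100000 nM, not a number. Compound 1 likewise gives only a limit, > 50000 nM. Compound 3 also stops at a limit, > 100000 nM. The change from compound 2 to compound 1 is cyano in place of fluoro on an aromatic carbon; its step, a step that the two limits leave unreadable from compound 2 to compound 1, cannot be read because both values are limits, two of them sitting at the limit of > 100000 nM in this assay, at which 2 of the 3 values shown sit, and one at the limit of > 50000 nM in this assay, at which 1 of the 3 values shown sits.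

Compound 4, `COc1ccc(-c2cnc(NC(=O)c3ccccc3C#N)n2C)cc1`, is not yet measured. It differs from compound 3 by cyano in place of fluoro on an aromatic carbon, the same kind of change as from compound 2 to compound 1, but here ortho to a large group rather than para to a large group. The difference between the core of compound 3 and the core of compound 2 is not broken down here.

For compound 4 a step that the limit leaves unreadable from compound 3 to compound 4 is expected, resting on compound 3 and its limit > 100000 nM. Compound 4 is therefore estimated at 150000 nM, most likely again only a limit.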

Compound 4, half-maximal cytotoxic concentration: > 100000 nM
Compound 4: only a limit was reported; the forecaster's own chance of this, stated with the estimate: 80%; the middle value is on the limit's open side.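

In this assay compound 4 gives only a limit, > 100000 nM, not a number. Compound 3 also stops at a limit, so no step can be read between compound 3 and compound 4. The compounds shown leave open whether cyano in place of fluoro on an aromatic carbon changes this read-out at all, in either pair.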